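The source may report more compounds than this note shows. Statements on the series, on what has been measured and on what is new or still open speak of the compounds shown alone.

Of the compounds shown here, three sharing a common core have been measured in an in vitro functional assay on HEK293-A cells for positive allosteric modulation of metabotropic glutamate receptor 5 (Homo sapiens), read by FLIPR and calcium flux; a lower number here means that less compound is needed, a higher number that more compound is needed for the effect. Compound 1 `O=C1CC(c2nc(-c3ccc(Cl)cc3)no2)CN1c1ccc(Cl)c(Cl)c1` gives 1100 nM in this assay. Compound 2 `Cc1ccc(N2CC(c3nc(-c4cccc(F)c4)no3)CC2=O)cc1` gives 1200 nM in this assay. Compound 3 `O=C1CC(c2nc(-c3ccc(F)cc3)no2)CN1c1ccc(Cl)c(Cl)c1` gives 2300 nM in this assay. Compound 1 and compound 3 differ in a single place, (chloro in place of fluoro on an aromatic carbon), and this change produced a 2.1-fold lower number from compound 3 to compound 1 (0.32 log units; beyond the scatter). The difference between the cores of compound 2 and compound 3 is not broken down here.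

Compound 4 `Cc1ccc(N2CC(c3nc(-c4cccc(Cl)c4)no3)CC2=O)cc1` has not yet been measured. It differs from compound 2 by chloro in place of fluoro on an aromatic carbon. For the measured compounds named here, this is the same kind of change as the one from compound 3 to compound 1, but not the same: in compound 1 the entering chloro sits para to a large group, whereas in compound 4 it sits meta to a large group. Since the earlier change gave a 2.1-fold lower number from compound 3 to compound 1 (0.32 log units; beyond the scatter), a step of similar size is expected here, and the estimated step is a 1.7-fold lower number from compound 2 to compound 4 (0.23 log units; within the scatter). For compound 4 the estimated value in this assay is 700 nM, expected to fall between 350 nM and 1400 nM.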

Compound 4, half-maximal effective concentration: 630 nM
For compound 4 the middle estimate is 1.1-fold (0.05 log units) above the measured one; the range from low to high includes it.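

Putting chloro in place of fluoro on the aromatic ring of compound 2, the change from 3-fluorophenyl to 3-chlorophenyl, gives a 1.9-fold lower number from compound 2 to compound 4 (0.28 log units; within the scatter) in this assay. Set beside the same change on the other core, the two steps agree in direction and in size: the same change on two cores in this assay, a 2.1-fold lower number (0.32 log units; beyond the scatter) from compound 3 to compound 1 and a 1.9-fold lower number (0.28 log units; within the scatter) from compound 2 to compound 4, 1.1-fold (0.04 log units) apart, within the scatter of two such steps. Within these two pairs, then, the change carries over from one core to the other with much the same result, although the new step taken alone lies within the scatter, and two pairs are too few to make a rule for the series or to say how much the place of the chloro on the ring matters, since the core and that place both differ between the pairs.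

The compounds shown leave open how a bromo, methyl or methoxy group would compare with chloro and fluoro at these places on either core. From the compounds shown here alone, it also remains open whether an amine or a carboxylic acid there would be tolerated at all.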